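Adding an acetyl to the hydroxyethoxymethyl arm of compound 3

A few compounds are considered here, and "the series" means these few. Any claim that something is new, unique, unknown or untested is made for them only; others in the source may bear on it.

Compound 1, `CC(=O)OCCOCN1c2ccccc2C(=O)NS1(=O)=O`: in a functional assay on HEL cells (Homo sapiens) (a lower number here means that less compound is tolerated, a higher number that more compound is tolerated), compound 1 reaches only a limit, > 200 ug/mL.
Compound 2, `O=C1c2ccccc2NS(=O)(=O)N1Cc1ccccc1`: in this assay compound 2 also reaches only a limit, > 50 ug/mL.
Compound 3, `O=C1c2ccccc2N(COCCO)S(=O)(=O)N1Cc1ccccc1`: in this assay compound 3 gives 125 ug/mL.

Compound 3 is thus the only one of the three with a real number; the other two stop at a limit of the measurement, and the step that the limit leaves unreadable from compound 2 to compound 3 cannot be sized for that reason. Compound 4, `CC(=O)OCCOCN1c2ccccc2C(=O)N(Cc2ccccc2)S1(=O)=O`, differs from compound 3 by acetyl in place of hydrogen on an oxygen on a saturated carbon. For the measured compounds named here, no measured step carries this same change, so nothing directly tells its size. Compound 1 carries the acetylated arm without the benzyl group, and its value is a limit, which neither confirms nor denies a shift. Going by the values given here, with no step to lean on, no shift beyond the scatter is expected, and the number for compound 4 in this assay is estimated at 150 ug/mL, between 60 ug/mL and 400 ug/mL, an expected step of a 1.2-fold higher number from compound 3 to compound 4 (0.08 log units; within the scatter).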

Compound 4, half-maximal cytotoxic concentration: 100 ug/mL
Estimate against measurement, compound 4: 1.5-fold (0.18 log units) above; low and high end bracket the measured number.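

Acetyl in place of the hydrogen on this oxygen leaves the tolerated concentration essentially unchanged in this assay, with a 1.3-fold lower number from compound 3 to compound 4 (0.10 log units; within the scatter), so the hydroxy end of the arm can become an acetoxy end without a shift beyond the scatter when the benzyl group is present. With the acetylated arm kept the same, benzyl in place of hydrogen on the amide-type nitrogen gives an at least 2.0-fold lower number from compound 1 to compound 4 (0.30 log units; that floor lies within the scatter). That figure is only a floor, and the true size of the step stays unknown, since compound 1 reaches only a limit: the limit of > 200 ug/mL in this assay, at which 1 of the 4 values shown sits.

The steps that start from compound 2 cannot be read. Going by these compounds, it also remains open whether a longer acyl chain such as butyryl, or an acyl group carrying an amine, on this oxygen would move the number beyond the scatter.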